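Swapping the aryl ring on a shared core

The source may report more compounds than this note shows. Statements on the series, on what has been measured and on what is new or still open speak of the compounds shown alone.

Compound 1 `COc1cccc(/C=C/C(=O)c2ccc(OC)c3c2OC(C)(C)C=C3)c1` — > 10000 nM
Compound 2 `COc1ccc(C(=O)/C=C/c2ccsc2)c2c1C=CC(C)(C)O2` — > 10000 nM
Compound 3 `COc1ccc(C(=O)/C=C/c2cc(Cl)ccc2O)c2c1C=CC(C)(C)O2` — not yet measured

In a functional assay on HT-29 cells (Homo sapiens) for antiproliferative activity, read by MTT assay, with a stated time of 24 h (on this read-out higher numbers stand for weaker inhibition and lower numbers for stronger inhibition), compound 1 gives only a limit of the assay, > 10000 nM. Compound 2 also gives only a limit, > 10000 nM. The step that the two limits leave unreadable from compound 1 to compound 2 cannot be read because the limit of > 10000 nM in this assay, at which 2 of the 2 values shown sit, holds both values. Compound 3 differs from compound 1 by 5-chloro-2-hydroxyphenyl in place of 3-methoxyphenyl on a double-bonded chain carbon bound to a double-bonded chain carbon. Among the measured compounds shown here, no measured step bears on this change, and compound 1 stands only at a limit, so the direction of the step is open. Compound 3 is expected to come out near 15000 nM, within 4000 nM to 50000 nM. That estimate means a step that the limit leaves unreadable from compound 1 to compound 3, most likely another limit.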

Compound 3, half-maximal inhibitory concentration: 4970 nM
The estimate for compound 3 lay 3.0-fold (0.48 log units) above the measured number, and the stated range covers the measured number.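

In this assay, among the compounds shown here, compound 3 is the first of the three compounds to give a number rather than a limit, so the ring at this chain carbon now has a measured point. Putting 5-chloro-2-hydroxyphenyl there gives an at least 2.0-fold lower number from compound 1 to compound 3 (0.30 log units; that floor lies within the scatter) and an at least 2.0-fold lower number from compound 2 to compound 3 (0.30 log units; that floor lies within the scatter). Each step is only a floor that lies within the scatter, and its true size stays unknown: the limit of > 10000 nM in this assay, at which 2 of the 3 values shown sit.

The chloro and hydroxy groups enter together, so the compounds shown do not separate their contributions. As far as these compounds go, whether a phenyl ring bearing an amine or a carboxylic acid would lower the number further also stays open.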